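This account rests on a few compounds, and the source may have more. Where it says the series, first, only, none or still open, it means among the compounds named here.

Measured compounds:
compound 1 `Cc1cc(C)c2sc(NC(=O)c3ccc(C#N)cc3)nc2c1` with 1.18 ug/mL
compound 2 `Cc1cc2nc(NC(=O)Nc3ccccc3C)sc2cc1C` with 0.18 ug/mL
compound 3 `COc1cccc2sc(NC(=O)c3ccc(C#N)cc3)nc12` with > 10 ug/mL

In a functional assay on SK-HEP1 cells (Homo sapiens) for antiproliferative activity, read by sulforhodamine B assay (on this read-out higher numbers stand for weaker inhibition of growth and lower numbers for stronger inhibition of growth), compound 1 gives 1.18 ug/mL. Of the two compounds that yield a number in this assay, compound 1 has the higher one; compound 2 gives 0.18 ug/mL, a lower number, and the gap between these two values lies beyond the usual scatter. For compound 3 the readout is > 10 ug/mL, which is the limit of > 10 ug/mL in this assay, at which 1 of the 3 values shown sits, and not a number, so it cannot be ranked against the others.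

Compound 4 `Cc1ccc(C(=O)Nc2nc3cc(C)cc(C)c3s2)cc1` differs from compound 1 in a single place: methyl in place of cyano on an aromatic carbon. Going by the values given here, no measured pair shows this particular change, so the size of the step must be guessed rather than read. The expected step is a 1.7-fold higher number from compound 1 to compound 4 (0.23 log units; within the scatter), modest and toward a somewhat higher number, with wide uncertainty on both sides. Compound 4 is therefore estimated at 2 ug/mL, with a likely range from 0.6 ug/mL to 7 ug/mL.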

Compound 4, concentration for 50% growth inhibition: 2.17 ug/mL
For compound 4 the middle estimate is 1.1-fold (0.04 log units) below the measured one; the range from low to high includes it.
By their numbers in this assay, from the lowest: compound 2; then compounds 1 and 4 (each within the scatter of the next). At a limit, above all of these: compound 3.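

In this assay, replacing cyano with methyl on this aromatic carbon, para to a large group, gives a 1.8-fold higher number from compound 1 to compound 4 (0.26 log units; within the scatter). Going by these compounds alone, this is the first comparison in the set that changes one place alone, and it shows that this position accepts the swap with no change beyond the scatter, even though the triple bond and the hydrogen-bond acceptor counted for cyano are gone. Nothing measured here bears on why the two groups read so alike.

Going by these compounds, whether an amine or a carboxylic acid at this same position would also stay within the scatter of compound 1 remains open. Compound 3 carries the same cyano on a different core, and its > 10 ug/mL is a limit, so whether methyl would behave alike on that core is also unsettled.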